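Chloro placement on the benzyl group of the shared core

A few compounds are considered here, and "the series" means these few. Any claim that something is new, unique, unknown or untested is made for them only; others in the source may bear on it.

Measured compounds and their numbers:
- compound 1 `CCCSc1nc(N/N=C(\C)c2ccccc2O)c2nnn(Cc3cccc(Cl)c3)c2n1` gives 13000 nM
- compound 2 `CCCSc1nc(N/N=C/c2cccnc2)c2nnn(Cc3ccccc3)c2n1` gives > 64000 nM, which is a limit of the assay and not a number
- compound 3 `CCCSc1nc(N/N=C(\C)c2ccccc2O)c2nnn(Cc3ccccc3)c2n1` gives 11100 nM

In a functional assay on ECa-109 cells (Homo sapiens) for antiproliferative activity, read by MTT assay, with a stated time of 72 h (a higher number here means a weaker inhibitor, a lower number a stronger inhibitor), compound 3 stands at the lowest of the two numbers shown. Compound 1 is nearest, and the step of a 1.2-fold lower number from compound 1 to compound 3 (0.07 log units; within the scatter) lies within the scatter. For compound 2 the assay reports only a limit. Going by the values given here, the step of an at least 5.7-fold lower number from compound 2 to compound 3 (0.76 log units; beyond the scatter) is therefore given as at least that size and is the one step in the set beyond the scatter; it rests on (the limit of > 64000 nM in this assay, at which 1 of the 3 values shown sits).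

Compound 4 `CCCSc1nc(N/N=C(\C)c2ccccc2O)c2nnn(Cc3ccc(Cl)cc3)c2n1` differs from compound 3 by chloro in place of hydrogen on an aromatic carbon. Among the compounds with values here, the one measured step that bears on this is a 1.2-fold lower number from compound 1 to compound 3 (0.07 log units; within the scatter), where hydrogen in place of chloro on an aromatic carbon of the benzyl group moved the number by an amount within the scatter. The change to compound 4 puts a chloro back onto the same ring, at the place described as para to a large group. No step beyond the scatter is expected in this assay in either direction. Compound 4 is expected to give about 12000 nM, within 5500 nM to 28000 nM. The expected step of a 1.1-fold higher number from compound 3 to compound 4 (0.03 log units; within the scatter) is thus estimated to stay within the scatter.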

Compound 4, half-maximal inhibitory concentration: 11200 nM
The estimate for compound 4 lay 1.1-fold (0.03 log units) above the measured number; measured number inside the range.
By their numbers in this assay, from the lowest: compounds 3, 4 and 1 (each within the scatter of the next). At a limit, above all of these: compound 2.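

In this assay, chloro in place of hydrogen on the aromatic carbon para to a large group gives a 1.0-fold higher number from compound 3 to compound 4 (0.00 log units; within the scatter), so benzyl and 4-chlorobenzyl cannot be told apart on the shared core. The comparison of chloro placements, 4-chlorophenyl in place of 3-chlorophenyl, gives a 1.2-fold lower number from compound 1 to compound 4 (0.06 log units; within the scatter), which extends the earlier finding for 3-chlorobenzyl: compounds 1, 3 and 4 all lie within the scatter of one another, and neither chloro placement stands apart from the other or from the unsubstituted benzyl group. Nothing measured here bears on a cause for this flat result.

Open is whether the benzyl ring tolerates only chloro or also a larger or different group, such as an amine or a carboxylic acid, since chloro is the only group shown on that ring. Going by these compounds alone, compound 2, whose > 64000 nM is a limit of the assay and not a number, is the only compound changed outside the benzyl group, and that part of the series rests on this single limit.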